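A few compounds are considered here, and "the series" means these few. Any claim that something is new, unique, unknown or untested is made for them only; others in the source may bear on it.

Compound 1 `COc1cc(-c2ccnc3cc(-c4c[nH]c5ccccc45)nn23)cc(OC)c1OC` gives 40 nM in a functional assay on B16-F0 cells (Mus musculus) for inhibition, read by CCK-8 assay, with a stated time of 48 h (on this read-out higher numbers stand for weaker inhibition and lower numbers for stronger inhibition), the lowest of the two numbers obtained so far. Compound 2 `COc1cc(-c2ccnc3cc(-c4ccc(-c5cnn(C)c5)cc4)nn23)cc(OC)c1OC` gives 1240 nM in this assay. Compound 3 `CCOC(=O)c1ccc(-c2cc3nccc(-c4cc(OC)c(OC)c(OC)c4)n3n2)cc1` gives only a limit in this assay, > 10000 nM. Within the data shown here, the one measured step, an at least 8.0-fold higher number from compound 2 to compound 3 (0.90 log units; beyond the scatter), runs into (the limit of > 10000 nM in this assay, at which 1 of the 3 values shown sits), so its full size is not known. Compound 4 `COc1cc(-c2ccnc3cc(-c4ccc(C)c(C)c4)nn23)cc(OC)c1OC` differs from compound 1 by 3,4-dimethylphenyl in place of 1H-indol-3-yl on an aromatic carbon. Among the measured compounds shown here, no measured step covers this change; the nearest guide is that compound 1 with 1H-indol-3-yl gives 40 nM while compound 2 with a substituted phenyl gives 1240 nM. A weaker result is therefore expected for compound 4, a 10-fold higher number from compound 1 to compound 4 (1.00 log units; beyond the scatter), with the estimate 400 nM spanning 100 nM to 2000 nM.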

Compound 4, half-maximal inhibitory concentration: 391 nM
For compound 4 the middle estimate is 1.0-fold (0.01 log units) above the measured one; the measured number falls inside the stated range.
By their numbers in this assay, from the lowest: compound 1; then compound 4; then compound 2. At a limit, above all of these: compound 3.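

Among these compounds, the swap in this assay gives a 9.8-fold higher number from compound 1 to compound 4 (0.99 log units; beyond the scatter), so at this position 1H-indol-3-yl outperforms a phenyl ring carrying only two methyl groups. The change removes the five-membered ring and the hydrogen-bond donor together, so the two cannot be separated, yet compound 4 remains on the low side of compound 2, which gives 1240 nM. Nothing at hand explains the size of this step.

Open, as far as these compounds go, is whether the indole ring hydrogen matters, which a 1-methylindol-3-yl group would test. Also open, from the compounds shown here alone, is how an amine on the phenyl ring would compare.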